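The compounds below may be only part of what the source reports. "The series", "measured", "known", "first", "only" and "open" are said of these compounds alone.

Three compounds share one core and differ only in the group on a nitrogen on an aromatic ring. Compound 1 `CCCCCCCCNc1nc(SCc2ccc(C(F)(F)F)cc2)nc2ccccc12` carries an octyl group there; in a functional assay on PC-3 cells (Homo sapiens) for cytotoxicity, read by MTT assay, with a stated time of 72 h (a lower number here means a stronger inhibitor, a higher number a weaker inhibitor), compound 1 gives 10500 nM. Compound 2 `COc1ccccc1Nc1nc(SCc2ccc(C(F)(F)F)cc2)nc2ccccc12` carries a 2-methoxyphenyl group, and in this assay compound 2 gives 14100 nM. Compound 3 `O=[N+]([O-])c1cccc(Nc2nc(SCc3ccc(C(F)(F)F)cc3)nc3ccccc23)c1` carries a 3-nitrophenyl group, and in this assay compound 3 gives 13500 nM. Compound 2 stands among these three with no gap to either of the others beyond the scatter: there is a 1.3-fold higher number from compound 1 to compound 2 (0.13 log units; within the scatter), a 1.0-fold lower number from compound 2 to compound 3 (0.02 log units; within the scatter), and, between the other two, a 1.3-fold higher number from compound 1 to compound 3 (0.11 log units; within the scatter).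

Compound 4 `Cc1ccc(Nc2nc(SCc3ccc(C(F)(F)F)cc3)nc3ccccc23)cc1` has not yet been measured. It differs from compound 2 in one place: 4-methylphenyl in place of 2-methoxyphenyl on a nitrogen on an aromatic ring. All three measured steps bear on this change, since each of them exchanges the whole group on that nitrogen, and none of them moved the number beyond the scatter. The exchange of 2-methoxyphenyl for 4-methylphenyl is expected to behave in the same way, giving no step beyond the scatter in this assay. The estimate for compound 4 is therefore 12000 nM, within 5000 nM to 30000 nM. That number means an expected 1.2-fold lower number from compound 2 to compound 4 (0.07 log units; within the scatter).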

Compound 4, half-maximal inhibitory concentration: 21100 nM
Compound 4: middle estimate off by 1.8-fold (0.25 log units), on the low side; the measured number falls inside the stated range.
By their numbers in this assay, from the lowest: compounds 1, 3, 2 and 4 (each within the scatter of the next).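

With 4-methylphenyl on the nitrogen, a fourth group has been tested at this position, and in this assay all three new comparisons stay within the scatter: a 1.5-fold higher number from compound 2 to compound 4 (0.18 log units; within the scatter), a 1.6-fold higher number from compound 3 to compound 4 (0.19 log units; within the scatter) and a 2.0-fold higher number from compound 1 to compound 4 (0.30 log units; within the scatter). The last of these is the widest gap printed for any pair of the four compounds, and the exchange of 2-methoxyphenyl for 4-methylphenyl shows that giving up the one hydrogen-bond acceptor counted in the group, while keeping its six-membered aromatic ring of carbon, yields no step beyond the scatter. No measurement shown gives a reason for these numbers or for how the compounds act on the cells.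

The compounds shown leave open whether any group on this nitrogen can produce a step beyond the scatter, as the four groups here are octyl and three substituted phenyl rings, and a chain ending in an amine, a morpholine ring or a carboxylic acid would test the position more widely. The rest of the core is identical in all four compounds, so they say nothing about how a change elsewhere would read in this cell assay.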